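Selenium for Sulfur in a Growth-Inactive Series

The source may report more compounds than this note shows. Statements on the series, on what has been measured and on what is new or still open speak of the compounds shown alone.

In a functional assay on CCRF-CEM cells (Homo sapiens) for cytotoxicity, read by MTT assay, with a stated time of 72 h (a higher number here means a weaker inhibitor of growth, a lower number a stronger inhibitor of growth), compound 1 `CCCCCSc1nc(NCc2ccc([Se]C)cc2)c2ccccc2n1` gives > 100000 nM, which is a limit of the assay and not a number. Compound 2 `CSc1nc(NCc2ccccc2)c2ccccc2n1` gives > 100000 nM in this assay, again a limit. Compound 3 `CSc1ccc(CNc2nc(SC)nc3ccccc23)cc1` gives > 100000 nM in this assay, once more a limit. Compound 3 thus stands exactly at the limit of > 100000 nM in this assay, at which 3 of the 3 values shown sit, and nothing places it higher or lower than its two companions. Within the data shown here, the only measured step, a step that the two limits leave unreadable from compound 2 to compound 3, cannot be read because both of its ends sit at the limit of > 100000 nM in this assay, at which 3 of the 3 values shown sit.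

Compound 4 `CSc1nc(NCc2ccc([Se]C)cc2)c2ccccc2n1` is the compound still to be measured. It differs from compound 3 in one place: a group of 2 heavy atoms (1 carbon, 1 selenium; no ring) in place of a group of 2 heavy atoms (1 carbon, 1 sulfur; no ring), on an aromatic carbon. Among the measured compounds shown here, no measured step covers this particular exchange. For the measured compounds named here, the one step that is available, from compound 2 to compound 3, concerns the methylsulfanyl group that now leaves, and it was unreadable. Compound 1 already carries the entering group and still sits at the limit.

With every measured value at the limit, the expected step of a number no higher from compound 3 to compound 4 (the limit leaves the size open) is none that could be read in this assay. Compound 4 is therefore expected to come out at about 100000 nM, within 30000 nM to 300000 nM, most likely again as a limit.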

Compound 4, concentration for total growth inhibition: > 100000 nM
Compound 4 was reported as a limit (the forecaster's own chance of this, stated with the estimate: 85%); the middle value sits exactly at the limit.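

None of the steps to compound 4 from compound 1, compound 2 or compound 3 can be read, because all four compounds sit at the same limit: the limit of > 100000 nM in this assay, at which 4 of the 4 values shown sit.

The compounds shown leave open whether the selenium-bearing group, in place of methylsulfanyl, changes growth inhibition in this assay at all; none of the values shown is a number.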